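Swapping a Large Aryl Substituent for Methoxy

This account rests on a few compounds, and the source may have more. Where it says the series, first, only, none or still open, it means among the compounds named here.

Measured compounds:
- Compound 1 `COc1cc(/C=C/C(C)=O)ccc1OCc1cn(-c2ccccc2CO)nn1`: 50300 nM
- Compound 2 `COc1cc(/C=C/C(C)=O)ccc1OCc1cn(-c2ccc(/N=N/c3ccccc3)cc2)nn1`: 42100 nM

Both measured compounds share a core and differ only in the group carried on the ring attached to the triazole. In a functional assay on PC-3 cells (Homo sapiens) for antiproliferative activity, read by MTT assay, with a stated time of 48 h (on this read-out higher numbers stand for weaker inhibition and lower numbers for stronger inhibition), compound 1 gives 50300 nM, and in this assay compound 2 gives 42100 nM. Compound 2 has the lowest of the two numbers, but its nearest neighbour, compound 1, lies within the scatter, so the two cannot be told apart on these data.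

Compound 3 `COc1ccc(-n2cc(COc3ccc(/C=C/C(C)=O)cc3OC)nn2)cc1` is the next step from compound 2. The change is a group of 2 heavy atoms (1 carbon, 1 oxygen; no ring) in place of a group of 8 heavy atoms (6 carbon, 2 nitrogen; one six-membered aromatic ring of carbon only), on an aromatic carbon, para to a large group. For the measured compounds named here, no step between measured compounds exists for this change, and the two measured numbers sit close together, so no step beyond the scatter is expected in this assay in either direction. Compound 3 is therefore estimated at 55000 nM, with a range from 22000 nM to 140000 nM, a step of a 1.3-fold higher number from compound 2 to compound 3 (0.12 log units; within the scatter) that is expected to stay within the scatter.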

Compound 3, half-maximal inhibitory concentration: 2010 nM
Compound 3: the middle estimate sits 27-fold (1.44 log units) above what was measured; measured number below the stated range.
By their numbers in this assay, from the lowest: compound 3; then compounds 2 and 1 (each within the scatter of the next).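

In this assay, methoxy in place of the group of 8 heavy atoms, on an aromatic carbon para to a large group, gives a 21-fold lower number from compound 2 to compound 3 (1.32 log units; beyond the scatter), and 4-methoxyphenyl in place of 2-(hydroxymethyl)phenyl on an aromatic nitrogen gives a 25-fold lower number from compound 1 to compound 3 (1.40 log units; beyond the scatter). Compound 1 and compound 2 carry very different groups here yet cannot be told apart, so they gave no sign that this part of the molecule matters; compound 3, the most potent of the three, shows that a change here can shift the number well beyond the scatter. Nothing measured here explains why methoxy has this effect.

Going by these compounds, what stays open is whether the gain belongs to methoxy itself or would also come with other groups in the same place, such as a fluorine atom, an amine or an ethoxy group. It is also unknown whether methoxy would keep this effect elsewhere on the same ring, and whether the same step would appear in a different assay.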